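Pyridin-3-yl Urea and Cytotoxicity in Kidney Cells

The source may report more compounds than this note shows. Statements on the series, on what has been measured and on what is new or still open speak of the compounds shown alone.

Compound 1 `Cc1cc(NC(=O)Nc2cccc(Cl)c2)c2ccccc2n1`: 21000 nM
Compound 2 `Cc1cc(NC(=O)Nc2ccc(F)cc2)c2ccccc2n1`: > 25000 nM (a limit of the assay, not a number)
Compound 3 `COC(=O)c1ccc(NC(=O)Nc2cc(C)nc3ccccc23)cc1`: 15000 nM

In an ADME assay on HEK293 cells (Homo sapiens) for cytotoxicity, with a stated time of 72 h (a higher number here means that more compound is needed for the effect, a lower number that less compound is needed), compound 1 gives 21000 nM and compound 3 gives 15000 nM, two values that lie within the usual scatter of each other. For compound 2 the assay reports only the limit > 25000 nM, so its true value is known only as a bound (the limit of > 25000 nM in this assay, at which 1 of the 3 values shown sits). Compound 2 thus stands at the edge of what this assay can report, and no number for it can be ranked against the others.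

Compound 4 `Cc1cc(NC(=O)Nc2cccnc2)c2ccccc2n1` differs from compound 2 in one place: pyridin-3-yl in place of 4-fluorophenyl on an amide-type nitrogen. Among the compounds with values here, two measured steps touch the same position. From compound 1 to compound 2 there was an at least 1.1-fold higher number from compound 1 to compound 2 (0.07 log units; that floor lies within the scatter), and from compound 2 to compound 3 there was an at least 1.6-fold lower number from compound 2 to compound 3 (0.22 log units; that floor lies within the scatter); both floors lie within the scatter and both involve a bound on compound 2. Neither step concerns a pyridin-3-yl group, so they offer no direction for this change. The expected step of a number no higher from compound 2 to compound 4 (the limit leaves the size open) is therefore none beyond the scatter, with a fair chance that compound 4 again returns only the limit.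

For compound 4 the estimate in this assay is 25000 nM, within 12000 nM to 50000 nM.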

Compound 4, half-maximal effective concentration: > 25000 nM
Compound 4: only a limit was reported; the forecaster's own chance of this, stated with the estimate: 55%; the middle value sits exactly at the limit.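

In this assay compound 4 is the second compound to return only a limit, not a number: the limit of > 25000 nM in this assay, at which 2 of the 4 values shown sit. The step between compound 2 and compound 4 cannot be read, as each has only a limit, so the exchange of 4-fluorophenyl for pyridin-3-yl has no measurable size here. With pyridin-3-yl in place of 3-chlorophenyl on the amide-type nitrogen, the record shows an at least 1.1-fold higher number from compound 1 to compound 4 (0.07 log units; that floor lies within the scatter), so this position now holds a six-membered aromatic ring with a hetero atom and one hydrogen-bond acceptor, and the assay still gives no readable number for it.

From the compounds shown here alone, the true values of compound 2 and compound 4 remain unknown, and so does any order between them. Also open, going by these compounds, is whether an amine or a carboxylic acid on the aromatic ring at this amide-type nitrogen, or a saturated ring such as piperidine in place of that aromatic ring, would give a number that can be read and compared.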